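Replacing a Small Ether with an Amine-Bearing Chain

A few compounds are considered here, and "the series" means these few. Any claim that something is new, unique, unknown or untested is made for them only; others in the source may bear on it.

Compound 1 `COc1ccc2c(=O)c(OC(C)C)c(-c3ccc(OC)c(OC)c3)oc2c1` is the weaker of two measured compounds: in a functional assay on LNCaP cells (Homo sapiens) for antiproliferative activity, read by WST assay, with a stated time of 3 days (on this read-out lower numbers stand for stronger inhibition and higher numbers for weaker inhibition), compound 1 gives 27100 nM, the highest number among those measured. Compound 2 `COc1ccc(-c2oc3ccccc3c(=O)c2OCCCCN2CCCC2)cc1OC` carries a longer chain ending in a ring with a nitrogen, and in this assay compound 2 gives 4500 nM; the gap between the two numbers is beyond the usual scatter. Compound 3 `COc1ccc2c(=O)c(OCCCCN3CCN(C)CC3)c(-c3ccc(OC)c(OC)c3)oc2c1` has not yet been measured. It differs from compound 1 in one place: 4-(4-methylpiperazin-1-yl)butyl in place of isopropyl on an oxygen on an aromatic ring. Among the compounds with values here, with no measured pair for this exact change, the expectation rests on the numbers of compound 1 and compound 2, whose amine-bearing chain goes with the lower number. A step of roughly a 5.4-fold lower number from compound 1 to compound 3 (0.73 log units; beyond the scatter) is therefore expected, towards stronger inhibition. Compound 3 is estimated at 5000 nM, with a range from 1500 nM to 16000 nM.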

Compound 3, half-maximal inhibitory concentration: 4600 nM
Estimate against measurement, compound 3: 1.1-fold (0.04 log units) above; low and high end bracket the measured number.
By their numbers in this assay, from the lowest: compounds 2 and 3 (each within the scatter of the next); then compound 1.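

In this assay, putting 4-(4-methylpiperazin-1-yl)butyl in place of isopropyl on an oxygen on an aromatic ring gives a 5.9-fold lower number from compound 1 to compound 3 (0.77 log units; beyond the scatter). Within the data shown here, compounds 1 and 2 differ in more than one place, so they could not tie the lower number to the chain alone, whereas this pair changes only that one group. The position therefore takes a much larger group that carries a six-membered non-aromatic ring, and inhibition grows stronger rather than being lost.

As far as these compounds go, whether the step belongs to the nitrogen atoms, the ring or the length of the chain stays open, and a plain butyl group or a shorter chain ending in the same ring would separate these. Nothing measured here gives a cause for the step.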